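Working notes: from compound 3 to compound 4

The source may report more compounds than this note shows. Statements on the series, on what has been measured and on what is new or still open speak of the compounds shown alone.

Measured so far in a functional assay on HeLa cells (Homo sapiens) for inhibition, read by MTT assay, with a stated time of 72 h; a higher number here means a weaker inhibitor, a lower number a stronger inhibitor:
- compound 1 `Cc1ccc(C(=O)/C=C/C(=O)O)cc1C` gives 7280 nM
- compound 2 `O=C(O)/C=C/C(=O)C1CCc2ccccc2C1` gives 7010 nM
- compound 3 `CCc1ccc(C(C)C)cc1C(=O)/C=C/C(=O)O` gives 4890 nM

Compound 3 at 4890 nM stands within the usual scatter of both compound 1 and compound 2, so these three values give no ranking. Going by the values given here, no two measured compounds differ in one place only, which leaves no measured step to guide the next one.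

Compound 4 `CC(C)c1ccc(C(C)C)c(C(=O)/C=C/C(=O)O)c1` differs from compound 3 by methyl in place of hydrogen on a saturated chain carbon bound to an aromatic carbon and a saturated chain carbon in one place: methyl in place of hydrogen on a saturated chain carbon bound to an aromatic carbon and a saturated chain carbon, which reads as ethyl to isopropyl.

In this assay no step beyond the scatter is expected, and neither direction is favoured. The support for this is limited: compound 1 at 7280 nM and compound 3 at 4890 nM differ in more than one place and still lie within the scatter of each other. The expected change is a 1.0-fold lower number from compound 3 to compound 4 (0.02 log units; within the scatter) and would stay within the scatter. For compound 4 the estimated value is 4700 nM, with an expected range of 2500 nM to 8500 nM.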

Compound 4, half-maximal inhibitory concentration: 4750 nM
For compound 4 the middle estimate is 1.0-fold (0.00 log units) below the measured one; the range from low to high includes it.
By their numbers in this assay, from the lowest: compounds 4, 3, 2 and 1 (each within the scatter of the next).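

In this assay, the one-place change of methyl in place of hydrogen on a saturated chain carbon bound to an aromatic carbon and a saturated chain carbon, which reads as ethyl to isopropyl, gives a 1.0-fold lower number from compound 3 to compound 4 (0.01 log units; within the scatter). This is the only step among the compounds shown that isolates a single place, and at this position ethyl and isopropyl cannot be told apart in this read-out, whereas the earlier comparisons all mixed differences in more than one place. No available evidence accounts for this result.

The compounds shown leave open whether the position stays within the scatter with a larger or different group, such as a tert-butyl, a longer chain like n-butyl, or an amine, since one small step between two alkyl groups gives no trend. They also leave open how the series responds at other places, for example with an amide in place of the carboxylic acid, as that group is common to every compound shown.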